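Aryl for Ester Chain on the Ring Nitrogen

The compounds below may be only part of what the source reports. "The series", "measured", "known", "first", "only" and "open" are said of these compounds alone.

Compound 1, `CCOC(=O)CN(Cc1ccccc1)c1nc(NCc2cccc(OC)c2)ncc1[N+](=O)[O-]`: in a functional assay on HepG2 cells (Homo sapiens) for antiproliferative activity, read by MTT assay, with a stated time of 48 h (on this read-out higher numbers stand for weaker inhibition and lower numbers for stronger inhibition), compound 1 gives 33600 nM.
Compound 2, `CCOC(=O)CNc1ncc([N+](=O)[O-])c(N(CC(=O)OCC)Cc2ccccc2)n1`: in this assay compound 2 gives 44500 nM.

Among the compounds with values here, of the two numbers so far, compound 2 carries the higher one, and its only neighbour is compound 1. Within the data shown here, the one known step, a 1.3-fold higher number from compound 1 to compound 2 (0.12 log units; within the scatter), is therefore a small one and within the scatter.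

Compound 3, `CCOC(=O)CN(Cc1ccccc1)c1nc(Nc2cccc(OC)c2)ncc1[N+](=O)[O-]`, has not yet been measured in this assay. It differs from compound 2 in one place: 3-methoxyphenyl in place of (ethoxycarbonyl)methyl on a nitrogen on an aromatic ring. Among the measured compounds shown here, the one measured step bears on this only loosely, since it exchanged the same two groups at a saturated chain carbon rather than at the ring nitrogen itself, and it moved the number little. On that basis no step beyond the scatter is expected in this assay in either direction, and the estimated step is a 1.3-fold lower number from compound 2 to compound 3 (0.10 log units; within the scatter). Compound 3 is accordingly expected to give about 35000 nM, with a range from 12000 nM to 100000 nM.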

Compound 3, half-maximal inhibitory concentration: 27600 nM
Estimate against measurement, compound 3: 1.3-fold (0.10 log units) above, within the range that was stated.
By their numbers in this assay, from the lowest: compounds 3, 1 and 2 (each within the scatter of the next).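

Exchanging the groups directly on the nitrogen on an aromatic ring, which the earlier pair did only at a saturated chain carbon, also stays within the scatter in this assay: 3-methoxyphenyl in place of (ethoxycarbonyl)methyl gives a 1.6-fold lower number from compound 2 to compound 3 (0.21 log units; within the scatter) at this nitrogen. Within the data shown here, a second change at the same place, 3-methoxyphenyl in place of 3-methoxybenzyl, gives a 1.2-fold lower number from compound 1 to compound 3 (0.09 log units; within the scatter) and is likewise within the scatter, so across compound 1, compound 2 and compound 3 this nitrogen carries an ester chain, a benzyl group and an aryl group with no step that stands out from repeated measurement. No measured evidence is available that would account for the size of these steps.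

What the compounds shown leave open is whether a group of another kind on this nitrogen, such as a carboxylic acid in place of the ethyl ester, a basic amine at the end of the chain or a longer chain, would give a step beyond the scatter. They also leave open whether the position responds at all in this assay, since every step seen so far is within the scatter.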